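Swapping Methyl for Bromo in Compound 1

This account rests on a few compounds, and the source may have more. Where it says the series, first, only, none or still open, it means among the compounds named here.

For the measured compounds named here, in a functional assay on MCF7 cells (Homo sapiens) for antiproliferative activity, read by MTT assay, with a stated time of 48 h (a lower number here means a stronger inhibitor, a higher number a weaker inhibitor), compound 1 `Cc1ccc(-c2nnc(NC(=O)/C=C/c3ccc(C(F)(F)F)cc3)s2)cc1` gives 1.1 ug/mL, the higher of the two numbers measured so far, and compound 2 `COc1ccc(/C=C/C(=O)Nc2nnc(-c3ccc(C)cc3)s2)cc1` gives 0.35 ug/mL. Compound 3 `O=C(/C=C/c1ccc(C(F)(F)F)cc1)Nc1nnc(-c2ccc(Br)cc2)s1` keeps the trifluoromethyl group of compound 1 but carries bromo in place of methyl on an aromatic carbon, turning 4-methylphenyl to 4-bromophenyl: bromo in place of methyl on an aromatic carbon. Going by the values given here, the only measured step, a 3.1-fold lower number from compound 1 to compound 2 (0.50 log units; beyond the scatter), is modest and comes from a different change, methoxy in place of trifluoromethyl. Among the compounds with values here, it therefore offers only a rough sense of scale, and no measured step shows what replacing methyl does. In this assay, no clear shift in either direction is expected. The estimated step is a 1.1-fold lower number from compound 1 to compound 3 (0.04 log units; within the scatter), which would stay within the scatter. For compound 3 the expected value is 1 ug/mL, with an estimated range from 0.35 ug/mL to 3 ug/mL.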

Compound 3, half-maximal inhibitory concentration: 1.58 ug/mL
Beside the measured number, compound 3's estimate is 1.6-fold (0.20 log units) below it; measured number inside the range.
By their numbers in this assay, from the lowest: compound 2; then compounds 1 and 3 (each within the scatter of the next).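

In this assay, the change from 4-methylphenyl to 4-bromophenyl gives a 1.4-fold higher number from compound 1 to compound 3 (0.16 log units; within the scatter), so for this pair, methyl and bromo cannot be told apart at this place on the ring. For the compounds shown here, this is the first measured view of this position, since the earlier step concerned the replacement of trifluoromethyl by methoxy on the other aromatic group. Nothing on hand explains why the swap leaves the number within the scatter.

Two groups of similar size in heavy atoms say little about what a larger or charged group would do here, such as an amine or a carboxylic acid on the same carbon. On these data alone, it also remains open whether bromo would behave the same way alongside the methoxy group of compound 2.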